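A few compounds are considered here, and "the series" means these few. Any claim that something is new, unique, unknown or untested is made for them only; others in the source may bear on it.

Compound 3 `O=S(=O)(CC1=NCCS1)C1=NNCC1c1ccc(Cl)cc1` is recorded in a functional assay, tested at 75 ug/mL (a higher number here means a stronger effect of the compound at the concentration tested, a lower number a weaker effect), as "not active" (no number reported), so no number is attached to it. Compound 1 `O=S(=O)(CC1=NCCO1)C1=NNCC1c1ccccc1` is likewise recorded in this assay as "not active" (no number reported). Compound 2 `Cc1ccc(C2CNN=C2S(=O)(=O)CC2=NCCO2)cc1`, the only one of the three with a figure, gives 42.1% in this assay. Compound 4 `O=S(=O)(CC1=NCCO1)C1=NNCC1c1ccc(Cl)cc1` has not yet been measured; it differs from compound 3 by a group of 5 heavy atoms (3 carbon, 1 nitrogen, 1 oxygen; one five-membered non-aromatic ring with 2 hetero atoms) in place of a group of 5 heavy atoms (3 carbon, 1 nitrogen, 1 sulfur; one five-membered non-aromatic ring with 2 hetero atoms), on a saturated chain carbon bound to a sulfonyl sulfur. For the measured compounds named here, no measured pair isolates this change, so the size of the step to compound 4 in this assay is open; a modest rise from the unreported level of compound 3 would be expected, though it may not exceed the scatter. The activity of compound 4 in this assay is estimated at 20%, within 0% to 45%.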

Compound 4, a percentage reported as activity, at one concentration (the size of the read-out at that concentration, not a potency): "not active" (no number reported)
No number was reported for compound 4; the estimate stays without a comparison.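

In this assay compound 3 stands as "not active" (no number reported) and compound 4 as "not active" (no number reported), so no step can be read between them, and no evidence shown bears on this result. The compounds shown leave open whether exchanging the sulfur-containing ring for the oxygen-containing ring changes the effect at all.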